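From Cyclohexyloxy to Dimethoxyphenyl on a Shared Core

A few compounds are considered here, and "the series" means these few. Any claim that something is new, unique, unknown or untested is made for them only; others in the source may bear on it.

Compound 1 `CC(C(=O)NCc1ccc(C(F)(F)F)cc1OC1CCCCC1)c1ccc(NS(C)(=O)=O)c(F)c1` gives 0.7 nM in an assay on CHO cells for antagonist activity at transient receptor potential cation channel subfamily V member 1 (Homo sapiens), read by FLIPR (a higher number here means a weaker inhibitor, a lower number a stronger inhibitor), the highest of the three numbers seen so far. Among the measured compounds shown here, compound 2 `CC(C(=O)NCc1ccc(C(F)(F)F)cc1SC1CCCC1)c1ccc(NS(C)(=O)=O)c(F)c1` gives 0.3 nM and compound 3 `C[C@H](C(=O)NCc1ccc(C(F)(F)F)cc1SC1CCCCC1)c1ccc(NS(C)(=O)=O)c(F)c1` gives 0.3 nM in this assay; the single measured step, a 2.3-fold lower number from compound 1 to compound 2 (0.37 log units; beyond the scatter), is the only change at this position seen so far. Compound 4 `COc1cc(OC)cc(-c2cc(C(F)(F)F)ccc2CNC(=O)C(C)c2ccc(NS(C)(=O)=O)c(F)c2)c1` is not yet measured; it differs from compound 1 by 3,5-dimethoxyphenyl in place of cyclohexyloxy on an aromatic carbon. For the measured compounds named here, no measured step replaces the cyclohexyloxy group with an aromatic ring, so the modest step from compound 1 to compound 2 bears only loosely on it. Compound 4 is therefore expected to give a somewhat higher number, a 4.3-fold higher number from compound 1 to compound 4 (0.63 log units; beyond the scatter), with wide uncertainty. The estimate for compound 4 is 3 nM, between 0.6 nM and 15 nM.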

Compound 4, inhibition constant: 5.8 nM
Beside the measured number, compound 4's estimate is 1.9-fold (0.29 log units) below it; low and high end bracket the measured number.
By their numbers in this assay, from the lowest: compounds 2 and 3 (each within the scatter of the next); then compound 1; then compound 4.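

In this assay, the 3,5-dimethoxyphenyl group is the only replacement of the cyclohexyloxy group shown that raises the number, and the rise lies beyond the scatter (an 8.3-fold higher number from compound 1 to compound 4 (0.92 log units; beyond the scatter)). Measured against the cyclopentylsulfanyl group, the same aromatic ring gives a large gap (a 19-fold higher number from compound 2 to compound 4 (1.29 log units; beyond the scatter)), so this position does not treat these groups alike. Nothing measured here explains the change.

The compounds shown leave open whether the higher number follows from the aromatic ring itself or from its two methoxy groups, a question that a plain phenyl group or a pyridine ring at this position would address.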